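Chain extension toward the iodophenyl end of a sphingosine analogue

This account rests on a few compounds, and the source may have more. Where it says the series, first, only, none or still open, it means among the compounds named here.

Measured compounds:
Compound 1, `N[C@@H](CO)[C@H](O)/C=C/CCCCCCc1ccc(I)cc1`: 7230 nM
Compound 2, `N[C@@H](CO)[C@H](O)/C=C/CCCCCCCCc1ccc(I)cc1`: 5730 nM

Two compounds have been examined in an assay on isolated protein for inhibition of sphingosine kinase 2 (Homo sapiens); on this read-out lower numbers stand for stronger inhibition and higher numbers for weaker inhibition. Compound 1 gives 7230 nM in this assay. Compound 2 gives 5730 nM in this assay. Compound 2 has the lower of the two numbers, but its gap to compound 1 lies within the usual scatter of repeated measurements, so the two values show no difference that can be read as real.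

Compound 3, `N[C@@H](CO)[C@H](O)/C=C/CCCCCCCCCc1ccc(I)cc1`, has not been measured. Its structure differs from compound 2 in one place: 4-iodobenzyl in place of 4-iodophenyl on a saturated chain carbon, eight bonds along the chain from a double-bonded chain carbon. Among the measured compounds shown here, no step between measured compounds covers this kind of change, and the pair already in hand, compound 1 and compound 2, shows two values that sit within the scatter of each other. On that basis the step from compound 2 to compound 3 is expected to be small, with no direction that would stand out beyond the scatter, as the estimated step of a 1.1-fold lower number from compound 2 to compound 3 (0.06 log units; within the scatter) expresses. Compound 3 is therefore estimated at 5000 nM in this assay, with a range from 2000 nM to 15000 nM.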

Compound 3, half-maximal inhibitory concentration: 16600 nM
Compound 3: the middle estimate sits 3.3-fold (0.52 log units) below what was measured; the measured number lies above the stated range.
By their numbers in this assay, from the lowest: compounds 2 and 1 (each within the scatter of the next); then compound 3.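

In this assay the exchange of 4-iodophenyl for 4-iodobenzyl on a saturated chain carbon, eight bonds along the chain from a double-bonded chain carbon, gives a 2.9-fold higher number from compound 2 to compound 3 (0.46 log units; beyond the scatter) and thus a modest step toward weaker inhibition. The printed values of compound 1 and compound 2 lie within the scatter of each other and gave no sign of separation, whereas this change shows that the group at this position can shift the read-out beyond the scatter. The data at hand offer no measurement that accounts for this weaker inhibition.

Going by these compounds, whether a still longer chain would carry the weakening further or reverse it remains open, since a single step beyond the scatter defines no trend along the chain. On these data alone, it is equally open how a carboxylic acid, an amine or a bromine atom in place of the iodine would read in this assay and whether any such group would separate from compound 2 by more than the scatter.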